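Series notes: acylating the chain nitrogen of compound 3

A few compounds are considered here, and "the series" means these few. Any claim that something is new, unique, unknown or untested is made for them only; others in the source may bear on it.

Compound 3 `O=S(=O)(c1cccc(F)c1)c1ccc2c(c1)CCC[C@H]2CNCCO` gives 0.126 nM in an assay on isolated protein for displacement of a labelled ligand from 5-hydroxytryptamine receptor 6 (Homo sapiens); on this read-out higher numbers stand for weaker inhibition and lower numbers for stronger inhibition. Of the three numbers measured it is the second highest. Its nearest neighbour is compound 1 `O=C1CN=C(NC[C@@H]2CCCc3cc(S(=O)(=O)c4cccc(F)c4)ccc32)N1`, which in this assay gives 0.1 nM; the gap a 1.3-fold higher number from compound 1 to compound 3 (0.10 log units; within the scatter) is within the scatter, so no order between compound 3 and compound 1 is claimed. The furthest is compound 2 `O=C1CN(C[C@@H]2CCCc3cc(S(=O)(=O)c4cccc(F)c4)ccc32)CCN1`, which in this assay gives 6.31 nM, a step of a 50-fold lower number from compound 2 to compound 3 (1.70 log units; beyond the scatter).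

Compound 4 `CN(C)C(=O)NC[C@@H]1CCCc2cc(S(=O)(=O)c3cccc(F)c3)ccc21` awaits measurement. It differs from compound 3 by dimethylcarbamoyl in place of 2-hydroxyethyl on an amine nitrogen: the amine nitrogen keeps its hydrogen but now carries a carbonyl-bearing group instead of a chain ending in a hydroxyl.

For the measured compounds named here, two measured steps touch this position. The step of a 63-fold higher number from compound 1 to compound 2 (1.80 log units; beyond the scatter) and the step of a 50-fold lower number from compound 2 to compound 3 (1.70 log units; beyond the scatter) are both large, and both turn on what sits on the nitrogen attached to the chain carbon. Compound 4 departs from the open amine of compound 3 without repeating the ring of compound 2, so a step toward higher numbers, smaller than those two but beyond the scatter, is expected: a 12-fold higher number from compound 3 to compound 4 (1.08 log units; beyond the scatter). Compound 4 is therefore estimated at 1.5 nM in this assay, within 0.3 nM to 8 nM.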

Compound 4, inhibition constant: 2.51 nM
Compound 4: the middle estimate sits 1.7-fold (0.22 log units) below what was measured, and the stated range covers the measured number.
By their numbers in this assay, from the lowest: compounds 1 and 3 (each within the scatter of the next); then compound 4; then compound 2.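

Dimethylcarbamoyl on the amine nitrogen, read in this assay, gives the large step of a 20-fold higher number from compound 3 to compound 4 (1.30 log units; beyond the scatter), so an open chain at this nitrogen does not by itself keep the low numbers of compound 3, and a large rise does not need the ring carried by compound 2. The large step of a 25-fold higher number from compound 1 to compound 4 (1.40 log units; beyond the scatter) and the modest step of a 2.5-fold lower number from compound 2 to compound 4 (0.40 log units; beyond the scatter), which is still beyond the scatter, place this urea apart from both ring-bearing compounds, with the ring-free pair compound 3 and compound 4 lying on opposite sides of compound 2 in no simple order of ring against no ring. No measurement on hand accounts for these steps.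

The compounds shown leave open whether the higher number goes with the carbonyl on the nitrogen, with the methyl groups of the urea, or with the loss of the hydroxyl. An acetyl group, a methylcarbamoyl group and a 2-methoxyethyl chain on the same amine nitrogen would each bear on a different one of these readings.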